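The compounds below may be only part of what the source reports. "The series", "measured", "known", "first", "only" and "open" are said of these compounds alone.

Series notes. Compound 1 `COc1cc(-c2cc(/C=C/C(=O)c3ccc(N)cc3)[nH]n2)cc(OC)c1OC` and compound 2 `COc1ccc(-c2cc(/C=C/C(=O)c3ccc(OC)c(OC)c3)[nH]n2)cc1` have both been run in a functional assay on SK-OV-3 cells (Homo sapiens) for inhibition, read by sulforhodamine B assay, with a stated time of 48 h; on this read-out higher numbers stand for lower toxicity in this test and lower numbers for higher toxicity in this test. In this assay compound 1 gives 28900 nM. Compound 2 gives 43400 nM in this assay. Compound 1 holds the lower of the two numbers, yet the two values lie within the scatter of each other, so no order can be read from them. Compound 3 `COc1cc(-c2cc(/C=C/C(=O)c3ccc(Cl)c(Cl)c3)[nH]n2)cc(OC)c1OC` has not yet been measured in this assay. It differs from compound 1 in one place: 3,4-dichlorophenyl in place of 4-aminophenyl on a carbonyl carbon. Going by the values given here, no pair of measured compounds differs in a single place, so there is no measured step to lean on. The expectation for compound 3 is that the step of a 1.0-fold higher number from compound 1 to compound 3 (0.02 log units; within the scatter) stays within the scatter, with no clear direction. Compound 3 is thus estimated at 30000 nM in this assay, with a range from 10000 nM to 90000 nM.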

Compound 3, concentration lethal to 50% of the cells: 62500 nM
For compound 3 the middle estimate is 2.1-fold (0.32 log units) below the measured one, and the stated range covers the measured number.
By their numbers in this assay, from the lowest: compounds 1, 2 and 3 (each within the scatter of the next, the first and the last beyond it).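

In this assay the group on the carbonyl carbon now has its first measured single-place step: 3,4-dichlorophenyl in place of 4-aminophenyl gives a 2.2-fold higher number from compound 1 to compound 3 (0.33 log units; beyond the scatter) and so moves the series toward lower toxicity in this test. This shows that the position can shift the read-out, though only modestly. The change removes the amino group and brings in two chlorines at once, so this single step cannot separate the two, and no measured information on these groups bears on the step.

Still open, going by these compounds, is how unsubstituted phenyl, 4-chlorophenyl or 4-hydroxyphenyl would read on the same carbonyl carbon, which would help separate loss of the amino group from arrival of the chlorines. Also open, on these data alone, is whether the step carries over to a core other than that of compound 1.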